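Ethoxycarbonyl to 2-Fluorophenyl: Expected Cytotoxicity of Compound 3

A few compounds are considered here, and "the series" means these few. Any claim that something is new, unique, unknown or untested is made for them only; others in the source may bear on it.

Compound 1 `Cc1ncc([N+](=O)[O-])n1CC(O)CSC(=S)N1CCN(c2ccccc2F)CC1`: 3240000 nM
Compound 2 `CCOC(=O)N1CCN(CC(O)Cn2c([N+](=O)[O-])cnc2C)CC1`: 3670000 nM

In a toxicity assay on HeLa cells (Homo sapiens) for cytotoxicity, read by MTT assay, with a stated time of 24 h (on this read-out lower numbers stand for stronger inhibition and higher numbers for weaker inhibition), compound 2 gives 3670000 nM, the higher of the two numbers, yet compound 1 lies within the scatter of it, so the two cannot be ordered. Compound 3 `Cc1ncc([N+](=O)[O-])n1CC(O)CN1CCN(c2ccccc2F)CC1` is not yet measured. It differs from compound 2 by 2-fluorophenyl in place of ethoxycarbonyl on an amine nitrogen in a ring. For the measured compounds named here, no measured step of this kind exists. Compound 1 carries the same 2-fluorophenyl on a ring nitrogen and gives 3240000 nM, a number close to that of compound 2. A step within the scatter is therefore expected, a 1.2-fold lower number from compound 2 to compound 3 (0.09 log units; within the scatter). Compound 3 is expected to give about 3000000 nM, between 1000000 nM and 9000000 nM.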

Compound 3, half-maximal inhibitory concentration: > 5000000 nM
Compound 3: no number, only a limit; the forecaster's own chance of this, stated with the estimate: 20%; middle value at least 1.6-fold (0.22 log units) from the limit.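

In this assay compound 3 gives > 5000000 nM, which is a limit of the assay and not a number. Placing 2-fluorophenyl in place of ethoxycarbonyl on this amine nitrogen in a ring gives an at least 1.3-fold higher number from compound 2 to compound 3 (0.13 log units; that floor lies within the scatter), the first measured step at this position: it shows no stronger inhibition, but its full size stays unknown. This step rests on a limit: the limit of > 5000000 nM in this assay, at which 1 of the 3 values shown sits. As far as these compounds go, how far the true value of compound 3 lies past that limit remains open. Also open, from the compounds shown here alone, is what an acetyl or benzyl group would give on this ring nitrogen.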